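The source may hold more compounds than are shown below. What is called first, only, known or untested is meant among the compounds shown, and "the series" means these compounds.

Measured compounds:
- compound 1 `COc1cc(C(=O)N2CCC(O)C(C)C2)cc2nc(NCc3cccc(Cl)n3)oc12`: in an assay on isolated protein for inhibition of thyroid hormone receptor beta (Homo sapiens), read by fluorescence, with a stated time of 30 min (on this read-out lower numbers stand for stronger inhibition and higher numbers for weaker inhibition), compound 1 gives 580 nM
- compound 2 `COc1cc(C(=O)N2CCC(O)C(C)C2)cc2nc(NC3(c4cccc(Cl)c4)CC3)oc12`: in this assay compound 2 gives 120 nM

Compound 2 holds the lower of the two numbers; the single step shown is a 4.8-fold lower number from compound 1 to compound 2 (0.68 log units; beyond the scatter). Compound 3 `COc1cc(C(=O)N2CCC(O)C(C)C2)cc2nc(NC3(c4cccc(Cl)c4)CCC3)oc12` differs from compound 2 by 1-(3-chlorophenyl)cyclobutyl in place of 1-(3-chlorophenyl)cyclopropyl on a nitrogen on an aromatic ring. No measured step covers a change in the size of this non-aromatic ring; the one step shown replaced the whole group rather than enlarging the ring, so it bears only loosely on this change. In this assay no step beyond the scatter is therefore expected. Compound 3 is estimated at 150 nM (range 50 nM to 450 nM), an expected step of a 1.3-fold higher number from compound 2 to compound 3 (0.10 log units; within the scatter).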

Compound 3, half-maximal inhibitory concentration: 8200 nM
Estimate against measurement, compound 3: 55-fold (1.74 log units) below; the whole stated range lies below it.
By their numbers in this assay, from the lowest: compound 2; then compound 1; then compound 3.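

In this assay this position proves sharply sensitive to ring size: one added ring carbon, 1-(3-chlorophenyl)cyclobutyl in place of 1-(3-chlorophenyl)cyclopropyl, gives a 68-fold higher number from compound 2 to compound 3 (1.83 log units; beyond the scatter) and so removes the earlier gain. The cyclobutyl group also ranks behind the (6-chloropyridin-2-yl)methyl group, with a 14-fold higher number from compound 1 to compound 3 (1.15 log units; beyond the scatter) as the step. Nothing available explains this loss.

Still open, on these data alone, is whether 1-(3-chlorophenyl)cyclopentyl continues the trend or reverses it. Also open, as far as these compounds go, is how an open-chain 2-(3-chlorophenyl)propan-2-yl group compares with the cyclopropyl group.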